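This account rests on a few compounds, and the source may have more. Where it says the series, first, only, none or still open, it means among the compounds named here.

For the measured compounds named here, compound 2 `COc1cc(/C=C/C(C)=O)ccc1OCc1cn(-c2ccc([N+](=O)[O-])cc2)nn1` gives 46700 nM in a functional assay on PC-3 cells (Homo sapiens) for antiproliferative activity, read by MTT assay, with a stated time of 48 h (a lower number here means a stronger inhibitor, a higher number a weaker inhibitor), the lower of the two numbers measured so far. Compound 1 `COc1cc(/C=C/C(C)=O)ccc1OCc1cn(-c2ccc(NC(=O)c3ccccc3)cc2)nn1` gives 76800 nM in this assay, and the step of a 1.6-fold lower number from compound 1 to compound 2 (0.22 log units; within the scatter) stays within the scatter. Compound 3 `COc1cc(/C=C/C(C)=O)ccc1OCc1cn(-c2ccc(C=O)cc2)nn1` differs from compound 2 by formyl in place of nitro on an aromatic carbon. Going by the values given here, no measured step involves a formyl group, and the only measured change at this position left the number essentially unchanged, so little movement is anticipated. The step expected is a 1.0-fold lower number from compound 2 to compound 3 (0.02 log units; within the scatter), small and within the scatter. Compound 3 is therefore estimated at 45000 nM, with a range from 20000 nM to 100000 nM.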

Compound 3, half-maximal inhibitory concentration: 80700 nM
Compound 3: middle estimate off by 1.8-fold (0.25 log units), on the low side; the range from low to high includes it.
By their numbers in this assay, from the lowest: compounds 2, 1 and 3 (each within the scatter of the next).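

With formyl, this position has now carried three different groups in this assay, and none of the steps leaves the scatter: formyl in place of nitro gives a 1.7-fold higher number from compound 2 to compound 3 (0.24 log units; within the scatter), and formyl in place of benzamido gives a 1.1-fold higher number from compound 1 to compound 3 (0.02 log units; within the scatter). Nitro, formyl and benzamido therefore cannot be told apart here, even though benzamido is much the largest of the three. From the compounds shown here alone, whether an amine or a carboxylic acid at this position would stand apart from these three remains open. Nothing available explains why these groups read alike.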